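The source may hold more compounds than are shown below. What is called first, only, known or untested is meant among the compounds shown, and "the series" means these compounds.

Measured so far in a functional assay on A549 cells (Homo sapiens) for inhibition, read by sulforhodamine B assay, with a stated time of 48 h; on this read-out lower numbers stand for stronger inhibition of growth and higher numbers for weaker inhibition of growth:
compound 1 `COc1cc(C=C(C(=O)/C=C/c2ccc(OC)c(OC)c2)C(=O)/C=C/c2ccc(OC)c(OC)c2)ccc1O` gives 530 nM
compound 2 `COc1ccc(/C=C/C(=O)C(=Cc2ccc(O)cc2)C(=O)/C=C/c2ccc(OC)c(OC)c2)cc1OC` gives 420 nM

Compound 2 stands within the scatter of compound 1, so the two numbers set no order. Next is compound 3 `CCc1ccc(C=C(C(=O)/C=C/c2ccc(OC)c(OC)c2)C(=O)/C=C/c2ccc(OC)c(OC)c2)cc1` with ethyl in place of hydroxy on an aromatic carbon in words, ethyl in place of hydroxy on an aromatic carbon, para to a large group. Among the measured compounds shown here, the only measured step is a 1.3-fold lower number from compound 1 to compound 2 (0.10 log units; within the scatter) and it lies within the scatter. That step leaves the hydroxy in place, so nothing measured tests this change. No shift beyond the scatter is expected, and no direction is firmly favoured. The expected change is a 1.2-fold higher number from compound 2 to compound 3 (0.08 log units; within the scatter) as a rough estimate. For compound 3 the estimate is 500 nM with an expected range from 170 nM to 1500 nM on this thin basis.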

Compound 3, concentration for 50% growth inhibition: 630 nM
For compound 3 the middle estimate is 1.3-fold (0.10 log units) below the measured one, within the range that was stated.
By their numbers in this assay, from the lowest: compounds 2, 1 and 3 (each within the scatter of the next).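

In this assay, ethyl in place of hydroxy gives a 1.5-fold higher number from compound 2 to compound 3 (0.18 log units; within the scatter) and so, at this position on the aromatic ring, a group with no hydrogen-bond donor or acceptor still gives a number within the scatter of the hydroxy compound. The wider change to 4-ethylphenyl from 4-hydroxy-3-methoxyphenyl gives a 1.2-fold higher number from compound 1 to compound 3 (0.08 log units; within the scatter) and also stays within the scatter. No measurement bears on why these numbers stay so close.

On these data alone, whether an amine, a carboxylic acid or a longer chain at this position would give a step beyond the scatter remains open.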